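The source may hold more compounds than are shown below. What is called first, only, known or untested is meant among the compounds shown, and "the series" means these compounds.

Measured so far in an assay on HEK293 cells for agonist activity at transient receptor potential cation channel subfamily M member 8 (Homo sapiens), read by fluorescence and calcium flux, with a stated time of 15 min; on this read-out higher numbers stand for an effect only at larger amounts of compound and lower numbers for an effect already at smaller amounts:
compound 1 `Cc1ccc(OCC(=O)N(Cc2cccs2)c2ccn(C)n2)cc1` gives 855 nM
compound 2 `CCN(Cc1ccsc1)C(=O)COc1ccc(C)cc1` gives 88 nM
compound 3 `CCN(Cc1cccn1C)C(=O)COc1ccc(C)cc1` gives 21300 nM

Compound 1 stands second highest of these three numbers, nearer to compound 2 than to compound 3. Among the measured compounds shown here, the one measured step, a 240-fold higher number from compound 2 to compound 3 (2.38 log units; beyond the scatter), swaps a heteroaryl on the saturated chain carbon bound to the amide-type nitrogen, not on the nitrogen itself, so it bears only loosely on compound 4 `Cc1ccc(OCC(=O)N(Cc2cccs2)c2nccn2C)cc1`, which differs from compound 1 by 1-methyl-1H-imidazol-2-yl in place of 1-methyl-1H-pyrazol-3-yl on an amide-type nitrogen. That step shows a heteroaryl swap can move this assay a great deal, but gives no direction for the present change. No beyond-the-scatter shift is expected, and the step is estimated as a 1.4-fold higher number from compound 1 to compound 4 (0.15 log units; within the scatter). For compound 4 the estimate is 1200 nM, within 300 nM to 5000 nM.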

Compound 4, half-maximal effective concentration: 1790 nM
Estimate against measurement, compound 4: 1.5-fold (0.17 log units) below, within the range that was stated.
By their numbers in this assay, from the lowest: compound 2; then compound 1; then compound 4; then compound 3.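

In this assay, the place on the amide-type nitrogen distinguishes two rings with the same atoms joined differently: 1-methyl-1H-imidazol-2-yl in place of 1-methyl-1H-pyrazol-3-yl gives a 2.1-fold higher number from compound 1 to compound 4 (0.32 log units; beyond the scatter), a modest step. The earlier compounds shown here gave no direction for this change, and this pair now gives one, for this single swap only. Nothing at hand accounts for the difference. Still open, from the compounds shown here alone, is how an unmethylated imidazole, a phenyl or a chain carrying an amine would read on this nitrogen with the rest of compound 1 kept.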